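The source may report more compounds than this note shows. Statements on the series, on what has been measured and on what is new or still open speak of the compounds shown alone.

Working notes on the corticotropin-releasing factor receptor 1 series.

Of the compounds shown here, three have been measured in an in vitro assay on 293-EBNA cells for binding affinity to corticotropin-releasing factor receptor 1 (Homo sapiens); on this read-out lower numbers stand for stronger inhibition and higher numbers for weaker inhibition. Compound 1 `CCCC(C)Nc1nc(C)nc2c1nnn2-c1c(C)cc(C)cc1C` gives 7.1 nM, compound 2 `CCCC(CCC)Nc1nc(C)nc2c1nnn2-c1ccc(Br)cc1Br` gives 0.8 nM, and compound 3 `CCN(CC)c1nc(C)nc2c1nnn2-c1ccc(C(C)C)cc1Br` gives 25.3 nM. Compound 3 thus stands highest of the three numbers; its nearest neighbour is compound 1, which lies lower by more than the usual scatter, and compound 2 lies lower still, far beyond the scatter. No pair of these compounds differs in one place only, so no single step between measured compounds can be read off.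

Compound 4 `COCC(C)(C)Nc1nc(C)nc2c1nnn2-c1ccc(C(C)C)cc1Br` has not yet been measured. It differs from compound 3 in one place: (1-(methoxymethyl)-1-methylethyl)amino in place of diethylamino on an aromatic carbon. Compounds 1 and 2, which carry a branched alkylamino group in place of the diethylamino group of compound 3, both give lower numbers in this assay, so a move away from diethylamino is expected to lower the number rather than raise it. Compound 4 is therefore estimated at 6 nM, with a range of 2 nM to 20 nM. Going by the values given here, the expected step from compound 3 to compound 4 is a 4.2-fold lower number from compound 3 to compound 4 (0.62 log units; beyond the scatter), a drop beyond the scatter, though the added ether oxygen in compound 4 has no precedent among the measured compounds and leaves the estimate wide.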

Compound 4, inhibition constant: 195 nM
Beside the measured number, compound 4's estimate is 33-fold (1.51 log units) below it; measured number outside the range, above it.
By their numbers in this assay, from the lowest: compound 2; then compound 1; then compound 3; then compound 4.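

In this assay, going by these compounds alone, placing (1-(methoxymethyl)-1-methylethyl)amino instead of diethylamino on this aromatic carbon, next to the ring nitrogen, gives a 7.7-fold higher number from compound 3 to compound 4 (0.89 log units; beyond the scatter), the first step that can be read at a single place, and it shows that the number responds to the amino group here. The change is not a single feature: the leaving group has 0 hydrogen-bond donors, while the entering group has 1 hydrogen-bond donor, an ether oxygen and more heavy atoms, so the step cannot be assigned to any one of these differences. Nothing available bears on why the number rises with this exchange.

Going by these compounds, compounds 1 and 2 differ from compound 4 in more than one place, so it remains open whether their branched alkylamino groups would also raise the number on the aromatic substituent pattern of compound 3. Also open, on these data alone, is whether the rise belongs to the ether oxygen or to the branched carbon skeleton, a question that tert-butylamino or (1-(hydroxymethyl)-1-methylethyl)amino at this position, with the rest of compound 3 unchanged, would help to separate.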